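The source may hold more compounds than are shown below. What is called first, only, known or untested is meant among the compounds shown, and "the series" means these compounds.

- compound 1 `CCc1ccc(SCc2ccc(C(=O)Nc3ccccc3N)cc2)cc1` gives 25.7%
- compound 2 `Nc1ccccc1NC(=O)c1ccc(CSc2cccc(F)c2)cc1` gives 18.6%
- compound 3 `Nc1ccccc1NC(=O)c1ccc(CSCCc2ccccc2)cc1` gives 28.1%

In a functional assay on SMMC-7721 cells (Homo sapiens) for inhibition, read by CCK-8 assay, with a stated time of 72 h, tested at 2 uM (a higher number here means more inhibition of growth at the concentration tested, a lower number less inhibition of growth), compound 3 gives 28.1% and lies within the scatter of both other compounds. Compound 4 `Cc1cc(C)cc(SCc2ccc(C(=O)Nc3ccccc3N)cc2)c1` differs from it by one change (3,5-dimethylphenyl in place of phenethyl on a sulfur), with 3,5-dimethylphenyl in place of phenethyl on a sulfur. Among the compounds with values here, three measured steps concern the group at this same place. Phenethyl in place of 4-ethylphenyl gave a number 2.4 percentage points higher from compound 1 to compound 3 (within the scatter) and phenethyl in place of 3-fluorophenyl gave a number 9.5 percentage points higher from compound 2 to compound 3 (within the scatter) while the swap between the two substituted phenyl groups gave a number 7.1 percentage points lower from compound 1 to compound 2 (within the scatter) in the same read-out. None of these leaves the scatter, so no step beyond the scatter is expected in this assay and no direction can be claimed with confidence. The expected change is small, namely a number 4.1 percentage points lower from compound 3 to compound 4 (within the scatter) as an estimate. Compound 4 is therefore estimated at 24% with an expected range from 13% to 35% in this measurement.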

Compound 4, percent growth inhibition at one concentration: 29.1%
Compound 4: the middle estimate sits 5.1 percentage points below what was measured, and the stated range covers the measured number.
By their numbers in this assay, from the lowest: compounds 2, 1, 3 and 4 (each within the scatter of the next, the first and the last beyond it).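

In this assay, 3,5-dimethylphenyl on a sulfur gives a number 1 percentage points higher from compound 3 to compound 4 (within the scatter) and a number 3.4 percentage points higher from compound 1 to compound 4 (within the scatter) and so cannot be told apart from phenethyl or 4-ethylphenyl at this place. Within the data shown here, the change from 3-fluorophenyl gives a number 10.5 percentage points higher from compound 2 to compound 4 (beyond the scatter) and is the only step at this place that leaves the scatter, which shows that the group on the sulfur can shift growth inhibition, though only modestly and only for this one pair. No measurement at hand explains this step. As far as these compounds go, how an amine, a carboxylic acid or a longer chain on the sulfur would read in this assay stays open. Also open, from the compounds shown here alone, is whether the modest gap between 3-fluorophenyl and 3,5-dimethylphenyl would persist at other concentrations or in other cell lines.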